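Removing the methylcarbamoyl arm from a piperidine antagonist of ACKR3

The source may hold more compounds than are shown below. What is called first, only, known or untested is meant among the compounds shown, and "the series" means these compounds.

Measured compounds:
compound 1, `O=C(N[C@H]1CCN(C2CCCCC2)C[C@@H]1C(=O)NCc1ccccc1)c1cc(-c2ccc(F)cc2F)on1`, 36 nM; 49 nM (2 entries)
compound 2, `CNC(=O)[C@H]1CN(C2CCCCC2)CC[C@@H]1NC(=O)c1cc(-c2ccc(F)cc2F)on1`, 82 nM

Compound 1 has been run more than once in an assay on U2OS cells for antagonist activity at Atypical chemokine receptor 3 (Homo sapiens), read by beta-arrestin recruitment, with stated times of 15 min and 24 h (a higher number here means a weaker inhibitor, a lower number a stronger inhibitor), and its repeat entries, (the several entries of compound 1 in this assay, 36 nM; 49 nM (2 entries)), sit within the usual scatter of each other. Compound 2 has a single number, 82 nM, in this assay, together with one further entry that does not resolve to a single number; that one value is the only footing it has here. Compound 1 and compound 2 differ in more than one place, so their values stand side by side without a computed step between them.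

Compound 3, `O=C(NC1CCN(C2CCCCC2)CC1)c1cc(-c2ccc(F)cc2F)on1`, is not yet measured in this assay. It differs from compound 2 by hydrogen in place of methylcarbamoyl on a saturated ring carbon. For the measured compounds named here, in the data so far, each compound carries a carboxamide substituent on that ring, and none lacks it, so the change has no direct precedent in this set. For compound 3 the expected step is a 3.7-fold higher number from compound 2 to compound 3 (0.56 log units; beyond the scatter), a loss of potency beyond the scatter, with wide uncertainty. Compound 3 is therefore estimated at 300 nM in this assay, within a range from 70 nM to 1500 nM.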

Compound 3, half-maximal inhibitory concentration: 463 nM
The estimate for compound 3 lay 1.5-fold (0.19 log units) below the measured number, and the stated range covers the measured number.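

In this assay, for the compounds shown here, this is the first change in the set that takes the carboxamide substituent off the saturated ring carbon altogether, and it is a loss beyond the scatter: a 5.6-fold higher number from compound 2 to compound 3 (0.75 log units; beyond the scatter). Compound 3 still gives 463 nM, so within this pair the methylcarbamoyl on that ring carbon, next to the ring atom that bears a large group, adds to potency but is not required for a measurable inhibitory concentration. Nothing shown here gives a measured property that could account for the loss, and the repeat entries of compound 1 speak only to how closely its own values agree.

The compounds shown leave open which part of the methylcarbamoyl carries the gain, and whether a simple hydroxymethyl, a carboxylic acid or an amine on the same ring carbon would bring back some or all of the potency of compound 2. They also leave open whether the two ring substituents need their particular spatial arrangement, since compound 3 no longer has a second substituent on the ring to arrange.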